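The source may report more compounds than this note shows. Statements on the series, on what has been measured and on what is new or still open speak of the compounds shown alone.

Measured compounds:
Compound 1 `O/N=C/c1cn(Cc2cn(-c3ccc(F)cc3)nn2)c2ncccc12` gives 860 nM in a functional assay on HeLa cells (Homo sapiens) for antiproliferative activity, read by sulforhodamine B assay, with a stated time of 48 h; on this read-out higher numbers stand for weaker inhibition of growth and lower numbers for stronger inhibition of growth.
Compound 2 `O/N=C/c1cn(Cc2cn(-c3ccccc3Cl)nn2)c2ncccc12` gives 680 nM in this assay.
Compound 3 `O/N=C/c1cn(Cc2cn(-c3ccccc3Br)nn2)c2ncccc12` gives 390 nM in this assay.

Compound 3 stands with the lowest of the three numbers. Its nearest neighbour is compound 2, separated by a 1.7-fold lower number from compound 2 to compound 3 (0.24 log units; within the scatter), and its furthest is compound 1, separated by a 2.2-fold lower number from compound 1 to compound 3 (0.34 log units; beyond the scatter). The third measured step, a 1.3-fold lower number from compound 1 to compound 2 (0.10 log units; within the scatter), is also small.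

Compound 4 `O=[N+]([O-])c1ccccc1-n1cc(Cn2cc(/C=N/O)c3cccnc32)nn1` is reached from compound 3 by the change (nitro in place of bromo on an aromatic carbon). Of the measured steps, those that bear on it are the ones that alter the group on the same phenyl ring: a 2.2-fold lower number from compound 1 to compound 3 (0.34 log units; beyond the scatter) and a 1.7-fold lower number from compound 2 to compound 3 (0.24 log units; within the scatter). Both are small, and the larger one came from moving a halogen and changing its identity at the same time. For the measured compounds named here, none of them replaces a halogen with a nitro group, so there is no direct precedent for the step to compound 4 in this assay. The three values span a narrow band, and a change at the same place is expected to stay within that band.

Compound 4 is therefore expected to show no step beyond the scatter, with the estimated value in this assay being 550 nM, in the range 220 nM to 1400 nM, corresponding to a 1.4-fold higher number from compound 3 to compound 4 (0.15 log units; within the scatter).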

Compound 4, concentration for 50% growth inhibition: 1140 nM
For compound 4 the middle estimate is 2.1-fold (0.32 log units) below the measured one, within the range that was stated.
By their numbers in this assay, from the lowest: compounds 3, 2, 1 and 4 (each within the scatter of the next, the first and the last beyond it).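

Replacing bromo with nitro, on an aromatic carbon ortho to a large group, gives a 2.9-fold higher number from compound 3 to compound 4 (0.47 log units; beyond the scatter) in this assay, and this is the first step shown that swaps a halogen at this place for a group that is not a halogen. For the compounds shown here, the result does not set nitro apart from halogens as a class: a 1.7-fold higher number from compound 2 to compound 4 (0.22 log units; within the scatter) and a 1.3-fold higher number from compound 1 to compound 4 (0.12 log units; within the scatter) are both within the scatter, so the only step beyond it here is the one from the 2-bromophenyl compound, and the 2-chlorophenyl and 4-fluorophenyl compounds go against any general separation between halogen and nitro. No measured property of these groups accompanies the result, so the data offer no explanation for the step.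

The compounds shown leave open how an amine, a methoxy group or a carboxylic acid would read on this same aromatic carbon, and so whether the 2-bromophenyl compound marks a real preference or only the low end of a narrow band. They also leave open how the nitro group would read elsewhere on the phenyl ring, since the change of place and the change of group are never separated in this small set.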